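The source may hold more compounds than are shown below. What is called first, only, known or untested is meant among the compounds shown, and "the series" means these compounds.

Compound 1, `COc1ccc(-c2nn(-c3ccc(Cl)cc3)cc2C=O)cc1`: in a functional assay on the whole organism (strain Wistar albino) for inhibition, with Rattus norvegicus as the target, read by paw edema, with stated times of 1 h and 3 h, at a dose of 0.32 mmol/kg by the intraperitoneal route (a lower number here means less inhibition, a higher number more inhibition at the dose given (going by the name of the read-out)), compound 1 gives 57.6%.
Compound 2, `COc1ccc(/N=C\c2cn(-c3ccc(Cl)cc3)nc2-c2ccc(C)cc2)cc1`: in this assay compound 2 gives 48.9%.
Compound 3, `COc1ccc(-c2nn(-c3ccc(Cl)cc3)cc2/C=N\c2ccccc2)cc1`: in this assay compound 3 gives 72.6%.

Compound 3 stands highest of the three numbers. Compound 1 comes nearest, and compound 2 lies furthest below; both gaps are beyond the usual scatter of repeated measurements. The next compound, compound 4, `COc1ccc(/N=C\c2cn(-c3ccc(Cl)cc3)nc2-c2ccc(OC)cc2)cc1`, differs from compound 3 by a single change: methoxy in place of hydrogen on an aromatic carbon.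

Among the compounds with values here, no measured pair makes this same change, so no direct guide exists. Within the data shown here, the one measured step, a number 15 percentage points higher from compound 1 to compound 3 (beyond the scatter), alters a different part of the molecule and therefore says little about adding a methoxy group here. Among the measured compounds shown here, compound 2 sits well below compound 3, but no single step links those two compounds, so its number is only a loose hint that further substitution need not help.

On this thin basis, a step of a number 10.6 percentage points lower from compound 3 to compound 4 (beyond the scatter) is expected in this assay, a modest drop that may not exceed the scatter. Compound 4 is therefore estimated at 62%, within a range of 46% to 78%.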

Compound 4, a percentage reported as inhibition, in the whole organism at one dose (the size of the read-out at that dose, not a potency): 82.2%
Compound 4: the middle estimate sits 20.2 percentage points below what was measured, outside the stated range (above it).
By their numbers in this assay, from the lowest: compounds 2 and 1 (each within the scatter of the next); then compounds 3 and 4 (each within the scatter of the next).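

In this assay, adding methoxy at the position para to a large group gives a number 9.6 percentage points higher from compound 3 to compound 4 (within the scatter), so the phenyl to 4-methoxyphenyl change has no effect that can be told apart from ordinary scatter. Methoxy in place of methyl on a different aromatic carbon gives a number 33.3 percentage points higher from compound 2 to compound 4 (beyond the scatter), and the larger exchange on the core gives a number 24.6 percentage points higher from compound 1 to compound 4 (beyond the scatter), so these two differences are clear while the single added methoxy is not. Nothing available explains any of these numbers.

On these data alone, whether an amine, a carboxylic acid or a longer chain such as ethoxy at the para position would separate from hydrogen remains open. Also open, as far as these compounds go, is whether methyl at that same position would match methoxy.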